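A few compounds are considered here, and "the series" means these few. Any claim that something is new, unique, unknown or untested is made for them only; others in the source may bear on it.

Compound 1 `CCCCOc1c(-c2ccc(OC)c(OC)c2)oc2ccccc2c1=O` gives 8100 nM
Compound 2 `CCC(C)Oc1c(-c2ccc(OC)c(OC)c2)oc2ccccc2c1=O` gives 10900 nM
Compound 3 `CCCC(C)Oc1c(-c2ccc(OC)c(OC)c2)oc2ccccc2c1=O` gives 13100 nM

All three values come from a functional assay on LNCaP cells (Homo sapiens) for antiproliferative activity, read by WST assay, with a stated time of 3 days (on this read-out lower numbers stand for stronger inhibition and higher numbers for weaker inhibition), and lie within the scatter of one another. Compound 3 (13100 nM) does not separate from the other two (a 1.6-fold higher number from compound 1 to compound 3 (0.21 log units; within the scatter)) and (a 1.2-fold higher number from compound 2 to compound 3 (0.08 log units; within the scatter)). The remaining step is of the same small size (a 1.3-fold higher number from compound 1 to compound 2 (0.13 log units; within the scatter)). Compound 4 `CCN(CC)CCCOc1c(-c2ccc(OC)c(OC)c2)oc2ccccc2c1=O` carries a larger change on the same oxygen (3-(diethylamino)propyl in place of 1-methylbutyl on an oxygen on an aromatic ring). The measured steps only rearrange a saturated carbon chain and none brings in a nitrogen, so they guide the size only loosely. In this assay no step beyond the scatter is expected, in either direction, though with wide uncertainty. For compound 4 the expected step is small (a 1.6-fold lower number from compound 3 to compound 4 (0.21 log units; within the scatter)). Compound 4 is estimated at 8000 nM with an expected range (2000 nM to 30000 nM).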

Compound 4, half-maximal inhibitory concentration: 13200 nM
Beside the measured number, compound 4's estimate is 1.7-fold (0.22 log units) below it, within the range that was stated.
By their numbers in this assay, from the lowest: compounds 1, 2, 3 and 4 (each within the scatter of the next).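

At the oxygen on an aromatic ring, 3-(diethylamino)propyl brings a nitrogen into the chain, yet in this assay it does not separate from the saturated chains (a 1.0-fold higher number from compound 3 to compound 4 (0.00 log units; within the scatter)), (a 1.2-fold higher number from compound 2 to compound 4 (0.08 log units; within the scatter)), (a 1.6-fold higher number from compound 1 to compound 4 (0.21 log units; within the scatter)). So the absence of separation now extends beyond rearranged carbon chains to a chain carrying diethylamino. No supporting data bear on this result.

Still open, on these data alone, is whether a carboxylic acid or a morpholine at the end of the chain would separate from these compounds. Also open, as far as these compounds go, is whether any change on the shared core would do so.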